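Aryl sulfonate ureas: chain homologation on a second core

This account rests on a few compounds, and the source may have more. Where it says the series, first, only, none or still open, it means among the compounds named here.

Two cores are compared here, each carrying an aryl sulfonate ester and a chloropropyl urea. Compound 1 `CCc1ccccc1OS(=O)(=O)c1cccc(NC(=O)NCCCCl)c1` and compound 2 `CCCc1ccccc1OS(=O)(=O)c1cccc(NC(=O)NCCCCl)c1` share the first core; compound 3 `CCc1ccccc1OS(=O)(=O)c1ccc(NC(=O)NCCCCl)cc1` and the as yet unmeasured compound 4 `CCCc1ccccc1OS(=O)(=O)c1ccc(NC(=O)NCCCCl)cc1` share the second. The difference between the two cores, as seen between compound 1 and compound 3, is not broken down here.

In a functional assay on M21 cells (Homo sapiens) for cytotoxicity, read by sulforhodamine B assay, with a stated time of 48 h (a higher number here means a weaker inhibitor, a lower number a stronger inhibitor), compound 1 gives 24000 nM. In this assay compound 2 gives 15000 nM. The change from compound 1 to compound 2 is methyl in place of hydrogen on a saturated chain carbon, two bonds along the chain from an aromatic carbon, and the step it made was a 1.6-fold lower number from compound 1 to compound 2 (0.20 log units; within the scatter). In this assay compound 3 gives 15000 nM, which stands level with compound 2 at the digits recorded.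

Compound 4 arises from compound 3 by methyl in place of hydrogen on a saturated chain carbon, two bonds along the chain from an aromatic carbon, which is the same change, at the same place, as that from compound 1 to compound 2. For the measured compounds named here, no further measured example of this change exists, so the single step seen between compound 1 and compound 2 is the only guide.

For compound 4 the step is expected to be a 1.5-fold lower number from compound 3 to compound 4 (0.18 log units; within the scatter), resting on the near-neutral step from compound 1 to compound 2 a 1.6-fold lower number from compound 1 to compound 2 (0.20 log units; within the scatter). The estimate for compound 4 in this assay is 10000 nM, with a range from 5000 nM to 25000 nM expected to cover the usual spread of such results.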

Compound 4, half-maximal inhibitory concentration: 13000 nM
Estimate against measurement, compound 4: 1.3-fold (0.11 log units) below, within the range that was stated.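

In this assay the ethyl to propyl change gives a 1.2-fold lower number from compound 3 to compound 4 (0.06 log units; within the scatter) on the core of compound 3. Set beside the step on the core of compound 1, the change reads alike on the two cores: the same change on two cores in this assay, a 1.6-fold lower number (0.20 log units; within the scatter) from compound 1 to compound 2 and a 1.2-fold lower number (0.06 log units; within the scatter) from compound 3 to compound 4, 1.4-fold (0.14 log units) apart, within the scatter of two such steps. This shows that, for these two pairs, the change carries from one core to the other without a step that stands clear of the scatter, but it does not show that the propyl chain has a real effect on either core, and two pairs set no rule for any other core or assay.

All the compounds shown keep the chloropropyl urea and carry only ethyl or propyl on the sulfonate aryl group, so a longer chain such as butyl, a branched chain such as isopropyl, or an amine or a carboxylic acid in place of the propyl remains open. Also open, on these data alone, is whether any such group would give a step beyond the scatter in this assay, and whether the two cores would then part in their response to it.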